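A few compounds are considered here, and "the series" means these few. Any claim that something is new, unique, unknown or untested is made for them only; others in the source may bear on it.

In an ADME assay (liver) for pharmacokinetics, with Liver microsome (Homo sapiens) as the target, using microsomes (on this read-out lower numbers stand for a shorter-lived compound and higher numbers for a longer-lived compound), compound 1 `CCOc1cc(NC(=O)C2(NC(=O)c3ccc4c(C5CCCC5)c(-c5ncc(Cl)cn5)n(C)c4c3)CCC2)ccc1/C=C/C(=O)OCOP(=O)(O)O` gives 0.167 h and compound 2 `CCCCCCOC(=O)/C=C/c1ccc(NC(=O)C2(NC(=O)c3ccc4c(C5CCCC5)c(-c5ncc(Cl)cn5)n(C)c4c3)CCC2)cc1OCC` gives 17.9 h on the same core. For compound 3 `CCOc1cc(NC(=O)C2(NC(=O)c3ccc4c(C5CCCC5)c(-c5ncc(Cl)cn5)n(C)c4c3)CCC2)ccc1/C=C/C(=O)OCCOc1ccccc1` the reading > 5 h is a limit and not a number. Compound 4 `CCOc1cc(NC(=O)C2(NC(=O)c3ccc4c(C5CCCC5)c(-c5ncc(Cl)cn5)n(C)c4c3)CCC2)ccc1/C=C/C(=O)OCC(=O)N1CCCC1` differs from compound 3 at one place ((pyrrolidin-1-yl)carbonyl in place of phenoxymethyl on a saturated chain carbon bound to an oxygen next to a carbonyl group) with (pyrrolidin-1-yl)carbonyl in place of phenoxymethyl on a saturated chain carbon bound to an oxygen next to a carbonyl group.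

Two large steps beyond the scatter bear on this change, namely a 110-fold higher number from compound 1 to compound 2 (2.03 log units; beyond the scatter) and an at least 29-fold higher number from compound 1 to compound 3 (1.47 log units; beyond the scatter) and both show how far a change at this end of the molecule can move the read-out. The nearest comparison gives no size, as a step that the limit leaves unreadable from compound 2 to compound 3 makes plain. For the measured compounds named here, no measured step brings in a group with a five-membered non-aromatic ring, so the transfer is loose. The expectation rests on compound 1 at 0.167 h and compound 2 at 17.9 h as the two ends of the measured range, and the entering group is expected to land inside that range, nearer the upper end.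

For compound 4 the expected step is an at least 1.4-fold lower number from compound 3 to compound 4 (0.15 log units; that floor lies within the scatter) with a moderate shortening in this assay as the likelier direction. For compound 4 the estimated half-life is 3.5 h with an expected range from 0.8 h to 15 h and a report as a limit remains possible.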

Compound 4, half-life: 1.65 h
Beside the measured number, compound 4's estimate is 2.1-fold (0.33 log units) above it; the measured number falls inside the stated range.
By their numbers in this assay, from the lowest: compound 1; then compound 4; then compound 2.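

In this assay, for the compounds shown here, (pyrrolidin-1-yl)carbonyl on a saturated chain carbon bound to an oxygen next to a carbonyl group gives the first reading at this place that shortens the half-life relative to phenoxymethyl, an at least 3.0-fold lower number from compound 3 to compound 4 (0.48 log units; beyond the scatter), and the size printed there is only a bound. The reading for compound 3 is a limit and not a number: the limit of > 5 h in this assay, at which 1 of the 4 values shown sits. Against the two fully measured ends of the set, the new group places the half-life at an intermediate level, with an 11-fold lower number from compound 2 to compound 4 (1.04 log units; beyond the scatter) and a 9.9-fold higher number from compound 1 to compound 4 (0.99 log units; beyond the scatter), so this position tunes the read-out in graded steps and does not merely split the compounds into short-lived and long-lived ones.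

From the compounds shown here alone, the full size of the change from phenoxymethyl remains open, and the step between compound 2 and compound 3 cannot be read. Going by these compounds, it also remains open whether the shorter half-life follows the carbonyl, the ring nitrogen or the five-membered ring itself; an open-chain amide, a simple amine, a carboxylic acid or a longer chain at this place would help to separate these.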